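The source may hold more compounds than are shown below. What is called first, only, known or untested is meant among the compounds shown, and "the series" means these compounds.

Notes on the ester chain of the succinate series.

Compound 1 `CCCCCCOC(=O)CCC(=O)N1CCN(CCCOc2cc3c(Nc4ccc(F)c(Cl)c4)ncnc3cc2OC)CC1` carries a hexyl ester; in a functional assay on A549 cells (Homo sapiens) for cytotoxicity, read by MTT assay, with a stated time of 24 h, tested at 60 uM (on this read-out lower numbers stand for a stronger effect and higher numbers for a weaker effect at the one concentration tested), compound 1 gives 63.6%. Compound 2 `CCCCCCCCOC(=O)CCC(=O)N1CCN(CCCOc2cc3c(Nc4ccc(F)c(Cl)c4)ncnc3cc2OC)CC1` carries an octyl ester; in this assay compound 2 gives 26%. Among the measured compounds shown here, the one step measured so far is a number 37.6 percentage points lower from compound 1 to compound 2 (beyond the scatter). For the measured compounds named here, on the two numbers available compound 2 therefore stands lowest, with compound 1 its only neighbour and that gap beyond the scatter.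

Compound 3 `CCCCCCCCCCOC(=O)CCC(=O)N1CCN(CCCOc2cc3c(Nc4ccc(F)c(Cl)c4)ncnc3cc2OC)CC1` is the next member and is not yet measured in this assay. Its difference from compound 2: ethyl in place of hydrogen on a saturated chain carbon, eight bonds along the chain from an oxygen next to a carbonyl group. The step that bears on it is the same ethyl insertion six bonds along the chain from an oxygen next to a carbonyl group, which gave a number 37.6 percentage points lower from compound 1 to compound 2 (beyond the scatter). A further step in the same direction is expected, but a smaller one, because compound 2 already gives 26% and the read-out has less room to fall. The expected step is a number 11 percentage points lower from compound 2 to compound 3 (beyond the scatter). Compound 3 is thus estimated at 15%, with a range from 5% to 35%.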

Compound 3, a percentage reported as activity, at one concentration (the size of the read-out at that concentration, not a potency): 3.9%
Estimate against measurement, compound 3: 11.1 percentage points above, outside the stated range (below it).
By their numbers in this assay, from the lowest: compound 3; then compound 2; then compound 1.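

In this assay the same ethyl change, now on a saturated chain carbon eight bonds along the chain from an oxygen next to a carbonyl group, again moves the read-out downward, giving a number 22.1 percentage points lower from compound 2 to compound 3 (beyond the scatter) and showing that the fall seen further in along the chain does not end with compound 2. Read across the whole run, butyl in place of hydrogen on the carbon six bonds along the chain gives a number 59.7 percentage points lower from compound 1 to compound 3 (beyond the scatter), so the three compounds fall in the order of their chains, hexyl, octyl and decyl, and none of the three goes against that order. The compounds shown hold no measurement that explains why the read-out follows the chain in this way.

As far as these compounds go, whether a longer chain than that of compound 3 would lower the number further remains open, with compound 3 at 3.9% leaving little room on this scale. Also open, from the compounds shown here alone, is whether the order depends on a plain unbranched chain, which a branched chain or a chain ending in an amine or a carboxylic acid would test.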